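The source may report more compounds than this note shows. Statements on the series, on what has been measured and on what is new or still open speak of the compounds shown alone.

Working notes on the series. The shared core is the spiro ring system of compound 1 `COC1Cc2sccc2C2(CCNCC2)O1`, whose amine nitrogen carries no substituent; in an assay on membranes from brain for displacement of a labelled ligand from Sigma non-opioid intracellular receptor 1 (Cavia porcellus) (on this read-out lower numbers stand for stronger inhibition and higher numbers for weaker inhibition), compound 1 gives 602 nM. Compound 2 `COC1Cc2sccc2C2(CCN(CCCc3ccccc3)CC2)O1` carries a phenylpropyl chain on that nitrogen and in this assay compound 2 gives 2.4 nM. Compound 3 `COc1ccc(CN2CCC3(CC2)OC(OC)Cc2sccc23)cc1` carries a 4-methoxybenzyl group, and in this assay compound 3 gives 2.2 nM. Compound 3 thus gives the lowest number of the three, although the step of a 1.1-fold lower number from compound 2 to compound 3 (0.04 log units; within the scatter) is within the scatter, so compound 2 and compound 3 are not separated; only compound 1 stands apart from both.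

Compound 4 `COC1Cc2sccc2C2(CCN(Cc3ccc(F)cc3)CC2)O1` differs from compound 3 in one place: fluoro in place of methoxy on an aromatic carbon. Within the data shown here, no measured pair changes a substituent on that aromatic ring, so nothing bears directly on this step. Among the measured compounds shown here, the only exchange on the nitrogen substituent between two potent compounds, the step from compound 2 to compound 3, stayed within the scatter. On that basis a change beyond the scatter is not expected, and the step of a 1.4-fold higher number from compound 3 to compound 4 (0.13 log units; within the scatter) is the expected outcome. In this assay compound 4 is therefore estimated at 3 nM, with a range from 1 nM to 10 nM.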

Compound 4, inhibition constant: 0.62 nM
For compound 4 the middle estimate is 4.8-fold (0.68 log units) above the measured one; the whole stated range lies above it.
By their numbers in this assay, from the lowest: compound 4; then compounds 3 and 2 (each within the scatter of the next); then compound 1.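

In this assay, fluoro in place of methoxy on an aromatic carbon gives a 3.5-fold lower number from compound 3 to compound 4 (0.55 log units; beyond the scatter), so a change on this ring, para to a large group, moves the number beyond the scatter, whereas the earlier exchange on the nitrogen substituent did not. Among these compounds, the 4-fluorobenzyl group also stands apart from the phenylpropyl chain, with a 3.9-fold lower number from compound 2 to compound 4 (0.59 log units; beyond the scatter), and compound 4 is the only compound whose steps to all the others are beyond the scatter. Against the free amine, the step of a 970-fold lower number from compound 1 to compound 4 (2.99 log units; beyond the scatter) is the largest listed for the series.

No measurement at hand accounts for the lower number of compound 4. On these data alone, whether chloro, nitrile or plain hydrogen at the same place on that ring would give a similar number stays open, as does the outcome for a longer chain carrying the 4-fluorophenyl group on the nitrogen.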